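Adding a Second Chloro Where Both Parents Sit at the Limit

The compounds below may be only part of what the source reports. "The series", "measured", "known", "first", "only" and "open" are said of these compounds alone.

Two close relatives have been tested in a functional assay on HeLa cells (Homo sapiens) for cytotoxicity, with a stated time of 72 h; on this read-out higher numbers stand for weaker inhibition and lower numbers for stronger inhibition. Compound 1 `Clc1ccc(Cc2nn3cc(-c4ccc(Br)cc4)nc3s2)cc1` gives > 250000 nM, which is a limit of the assay rather than a number. Compound 2 `Clc1ccc(Cc2nn3c(Br)c(-c4ccc(Cl)cc4)nc3s2)cc1` likewise gives > 250000 nM, again a limit and not a number. Compound 2 therefore stands at the limit of > 250000 nM in this assay, at which 2 of the 2 values shown sit. Compound 3 `Clc1ccc(Cc2nn3c(Br)c(-c4ccc(Cl)cc4Cl)nc3s2)cc1` differs from compound 2 by chloro in place of hydrogen on an aromatic carbon. Going by the values given here, with no measured step to lean on, no change beyond the scatter is expected in this assay. Compound 3 is estimated at 300000 nM, within 100000 nM to 1000000 nM, most likely reported once more as a limit. The expected step that the limit leaves unreadable from compound 2 to compound 3 is expected to stay within the scatter.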

Compound 3, half-maximal inhibitory concentration: 118000 nM
For compound 3 the middle estimate is 2.5-fold (0.41 log units) above the measured one; the range from low to high includes it.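

Changing 4-chlorophenyl to 2,4-dichlorophenyl gives, in this assay, an at least 2.1-fold lower number from compound 2 to compound 3 (0.32 log units; beyond the scatter), so a chloro on this aromatic carbon, ortho to a large group, does move the read-out. Going by these compounds alone, compound 3 is also the only one of the three compounds with a number rather than a limit. As far as these compounds go, the full size of the step stays unknown because compound 2 gives only a limit: the limit of > 250000 nM in this assay, at which 2 of the 3 values shown sit.

From the compounds shown here alone, whether a methyl group, a methoxy group or an amine on the same carbon would also lower the number remains open.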